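The source may hold more compounds than are shown below. What is called first, only, known or untested is meant among the compounds shown, and "the series" means these compounds.

In a functional assay on HCT-116 cells (Homo sapiens) for antiproliferative activity, read by MTT assay, with a stated time of 48 h (on this read-out higher numbers stand for weaker inhibition and lower numbers for stronger inhibition), compound 1 (`COc1cc(-c2nnc3c(OC4CC4)cc(-c4ccc5[nH]ccc5c4)cn23)cc(OC)c1OC`) gives 275 nM as its half-maximal inhibitory concentration. In this assay, for the measured compounds named here, compound 2 (`COc1cc(-c2nnc3c(OCC(F)(F)F)cc(-c4ccc5c(ccn5C)c4)cn23)cc(OC)c1OC`) gives 483 nM and so stands within the usual scatter of compound 1, the only other compound measured so far. The two numbers cannot be told apart.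

Compound 3 (`COc1cc(-c2nnc3c(OC4CC4)cc(-c4ccc5c(ccn5C)c4)cn23)cc(OC)c1OC`) has not yet been measured. It is compound 2 with cyclopropyl in place of 2,2,2-trifluoroethyl on an oxygen on an aromatic ring. Going by the values given here, no measured pair differs in one place only, so the size of this change has no direct measure. Among the compounds with values here, the only measured compound carrying cyclopropyloxy is compound 1 at 275 nM and that value lies within the scatter of compound 2, so little movement is expected.

In this assay the step expected is a 1.4-fold lower number from compound 2 to compound 3 (0.14 log units; within the scatter) and it is small, pointing toward stronger inhibition but not beyond the scatter. The estimated value for compound 3 is 350 nM (expected range 140 nM to 880 nM).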

Compound 3, half-maximal inhibitory concentration: 135 nM
Compound 3: middle estimate off by 2.6-fold (0.41 log units), on the high side; measured number outside the range, below it.
By their numbers in this assay, from the lowest: compound 3; then compounds 1 and 2 (each within the scatter of the next).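

In this assay, cyclopropyl in place of 2,2,2-trifluoroethyl on the oxygen on an aromatic ring gives a 3.6-fold lower number from compound 2 to compound 3 (0.55 log units; beyond the scatter) and so moves the read-out beyond the scatter, which compounds 1 and 2, differing in two places, could not show. Methyl in place of hydrogen on an aromatic nitrogen gives a 2.0-fold lower number from compound 1 to compound 3 (0.31 log units; beyond the scatter) as a first direct measure of that change, so both single changes point toward stronger inhibition, and compound 3, which carries cyclopropyloxy and the methyl together, is the strongest inhibitor of the three. Nothing shown here gives a reason for either step.

From the compounds shown here alone, the step at the oxygen has been read only with methyl on the aromatic nitrogen, and the step at the nitrogen only with cyclopropyloxy, so it remains open whether either holds with the other group changed. An ethoxy or isopropoxy chain on the same oxygen, or ethyl on the aromatic nitrogen, would be needed to tell whether the cyclopropyl ring itself, the loss of fluorine or the size of the group goes with the lower number.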